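A few compounds are considered here, and "the series" means these few. Any claim that something is new, unique, unknown or untested is made for them only; others in the source may bear on it.

The study sets three measured amides beside one that is not yet measured. Compound 1 `CC(C)N(Cc1cccc(OCCCCCC(=O)O)c1)C(=O)c1ccc(-c2cccc3ccccc23)cc1` ends its side chain in a carboxy group, and compound 3 `CCOC(=O)CCCCCOc1cccc(CN(C(=O)c2ccc(-c3cccc4ccccc34)cc2)C(C)C)c1` carries an ethoxycarbonyl in its place. Compound 2 `CC(C)N(Cc1cccc(OCCCCCC(=O)O)c1)C(=O)c1ccc(-c2cc3ccccc3n2S(=O)(=O)c2ccccc2)cc1` has the same carboxy side chain as compound 1 but a different core; the difference between the two cores is not broken down here. Compound 4 `CCOC(=O)CCCCCOc1cccc(CN(C(=O)c2ccc(-c3cc4ccccc4n3S(=O)(=O)c3ccccc3)cc2)C(C)C)c1` stands to compound 2 as compound 3 stands to compound 1.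

In an ADME assay on HEK293 cells (Homo sapiens) for cytotoxicity, read by CellTiter-Glo and resazurin assay, with a stated time of 72 h (a lower number here means that less compound is needed, a higher number that more compound is needed for the effect), compound 1 gives only a limit, > 26000 nM. Compound 3 also gives only a limit in this assay, > 26000 nM. Compound 2 likewise gives only a limit in this assay, > 26000 nM. The change from compound 1 to compound 3 is ethyl in place of hydrogen on an oxygen next to a carbonyl group, and the step that the two limits leave unreadable from compound 1 to compound 3 cannot be sized because of the limit of > 26000 nM in this assay, at which 3 of the 3 values shown sit.

The same change, (ethyl in place of hydrogen on an oxygen next to a carbonyl group), leads from compound 2 to compound 4. With both partners of the measured pair resting at the limit and compound 2 resting there too, the new pair offers no reason to expect a readable departure from it. The step expected here is a step that the limit leaves unreadable from compound 2 to compound 4. Compound 4 is estimated at 35000 nM, between 15000 nM and 120000 nM, most probably reported again as a limit rather than a number.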

Compound 4, half-maximal effective concentration: > 26000 nM
Compound 4: a limit, no number; the forecaster's own chance of this, stated with the estimate: 85%; the middle value does not contradict the limit.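

Among these compounds, compound 4 gives only a limit in this assay, so the step to it from compound 2 cannot be read, any more than the one from compound 1 to compound 3: the limit of > 26000 nM in this assay, at which 4 of the 4 values shown sit. The compounds shown leave open whether carboxy and ethoxycarbonyl differ at all in this assay, with either core, given that none of the four yields a number there.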